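Replacing the aromatic group of compound 3

The source may hold more compounds than are shown below. What is called first, only, known or untested is meant among the compounds shown, and "the series" means these compounds.

compound 1 `O=C(N/N=C/c1ccc(F)cc1)Nc1cc2c(Nc3ccc(F)c(Cl)c3)ncnc2cc1O[C@H]1CCOC1`: "not active" (no number reported)
compound 2 `N#Cc1ccc(/C=N/NC(=O)Nc2cc3c(Nc4ccc(F)c(Cl)c4)ncnc3cc2O[C@H]2CCOC2)cc1`: 28100 nM
compound 3 `O=C(N/N=C/c1ccc(F)cc1Cl)Nc1cc2c(Nc3ccc(F)c(Cl)c3)ncnc2cc1O[C@H]1CCOC1`: 28400 nM

In a functional assay on PC-3 cells (Homo sapiens) for cytotoxicity, read by MTT assay, with a stated time of 72 h (a lower number here means a stronger inhibitor, a higher number a weaker inhibitor), compound 3 gives 28400 nM and compound 2 gives 28100 nM. These two numbers lie within the scatter of each other, so compound 3 stands level with compound 2, while compound 1 offers no number for comparison.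

Compound 4 `COc1ccc(/C=N/NC(=O)Nc2cc3c(Nc4ccc(F)c(Cl)c4)ncnc3cc2O[C@H]2CCOC2)cc1` keeps the shared core and changes one group: 4-methoxyphenyl in place of 2-chloro-4-fluorophenyl on a carbon with a double bond to nitrogen. The 4-methoxyphenyl group enters on a carbon with a double bond to nitrogen, in place of 2-chloro-4-fluorophenyl.

Among the measured compounds shown here, the one measured step at this place is a 1.0-fold higher number from compound 2 to compound 3 (0.00 log units; within the scatter), which stays within the scatter. Compound 1, which differs at the same place, gave "not active" (no number reported), so a change here can also leave no number at all. For the measured compounds named here, no measured step covers the 4-methoxyphenyl group itself. The expectation therefore rests on that single small step, and no change beyond the scatter is expected in this assay, in either direction. The expected change is a 1.1-fold higher number from compound 3 to compound 4 (0.02 log units; within the scatter). For compound 4 the estimated value is 30000 nM, with an expected range from 12000 nM to 70000 nM.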

Compound 4, half-maximal inhibitory concentration: 34100 nM
For compound 4 the middle estimate is 1.1-fold (0.06 log units) below the measured one; low and high end bracket the measured number.
By their numbers in this assay, from the lowest: compounds 2, 3 and 4 (each within the scatter of the next).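

The step of a 1.2-fold higher number from compound 3 to compound 4 (0.08 log units; within the scatter) in this assay shows that this place on a carbon with a double bond to nitrogen also accepts 4-methoxyphenyl, with 1 hydrogen-bond acceptor where 2-chloro-4-fluorophenyl has 0, without a move beyond the scatter. The step of a 1.2-fold higher number from compound 2 to compound 4 (0.08 log units; within the scatter) adds a direct comparison of methoxy with cyano on an aromatic carbon, and it also stays within the scatter, so compounds 2, 3 and 4 stand level in this assay. No evidence at hand accounts for this result.

Going by these compounds, whether an amine or a carboxylic acid on the aromatic ring, or a longer chain in place of methoxy, would give a number beyond the scatter remains open. Also open, on these data alone, is how compound 1, which gives no number, relates to the other three.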